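The compounds below may be only part of what the source reports. "The series", "measured", "known", "first", "only" and "open" are said of these compounds alone.

Compound 1 `O=[N+]([O-])c1cc(CSc2nnc(-c3ccccc3)n2Cc2ccccc2)cc([N+](=O)[O-])c1` and compound 2 `O=[N+]([O-])c1cc(CSc2nnc(-c3ccc(Cl)cc3)n2Cc2ccccc2)cc([N+](=O)[O-])c1` share one core, while compound 3 `O=[N+]([O-])c1cc(-c2nnc(SCc3ccc(Cl)cc3)n2Cc2ccccc2)cc([N+](=O)[O-])c1` is built on another core; how the two cores differ is not broken down here. In an ADME assay on A-431 cells (Homo sapiens) for cytotoxicity, with a stated time of 48 h (on this read-out higher numbers stand for weaker inhibition and lower numbers for stronger inhibition), compound 1 gives > 30000 nM, which is a limit of the assay rather than a number. Compound 2 gives > 30000 nM, again a limit. Compound 3 gives > 30000 nM, also a limit. The change from compound 1 to compound 2 is chloro in place of hydrogen on an aromatic carbon, and the step it made, a step that the two limits leave unreadable from compound 1 to compound 2, cannot be read, due to the limit of > 30000 nM in this assay, at which 3 of the 3 values shown sit. Compound 4 `O=[N+]([O-])c1cc(-c2nnc(SCc3ccc(Cl)c(Cl)c3)n2Cc2ccccc2)cc([N+](=O)[O-])c1` has not yet been measured; it differs from compound 3 by chloro in place of hydrogen on an aromatic carbon. This is the same kind of change as that from compound 1 to compound 2, but the place is not the same: in compound 2 the chloro sits para to a large group, whereas in compound 4 it sits ortho to a chloro group and meta to a large group. Given (the limit of > 30000 nM in this assay, at which 3 of the 3 values shown sit), the step from compound 3 to compound 4 is expected to be a step that the limit leaves unreadable from compound 3 to compound 4. Compound 4 is therefore estimated at 50000 nM, most likely reported once more as a limit.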

Compound 4, half-maximal inhibitory concentration: > 30000 nM
Compound 4: only a limit was reported; the forecaster's own chance of this, stated with the estimate: 85%; the middle value is on the limit's open side.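

No new step can be read between compound 3 and compound 4, and the chloro change on compound 3 gives no size, for one reason: the limit of > 30000 nM in this assay, at which 4 of the 4 values shown sit. The compounds shown leave open how strongly any of them acts in this assay, and whether chloro in place of hydrogen changes that on either core.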